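Working notes: bicyclic exchange from compound 3 to compound 4

The compounds below may be only part of what the source reports. "The series", "measured", "known", "first", "only" and "open" are said of these compounds alone.

Three urea compounds share one core and differ only in the bicyclic group on one aromatic ring. In a functional assay on NCI-H460 cells (Homo sapiens) for cytotoxicity, read by MTT assay, with a stated time of 72 h (a higher number here means a weaker inhibitor, a lower number a stronger inhibitor), compound 1 `O=C(Nc1ccc(-n2ncc3c(Br)cccc32)cc1)Nc1ccc(Cl)c(C(F)(F)F)c1` gives 1300 nM, compound 2 `Cc1cccc2c1cnn2-c1ccc(NC(=O)Nc2ccc(Cl)c(C(F)(F)F)c2)cc1` gives 2500 nM, and compound 3 `O=C(Nc1ccc(-n2ncc3cnccc32)cc1)Nc1ccc(Cl)c(C(F)(F)F)c1` gives 1400 nM. Compound 3 stands second highest of the three numbers; its nearest neighbour is compound 1, with a 1.1-fold higher number from compound 1 to compound 3 (0.03 log units; within the scatter), and the furthest is compound 2, with a 1.8-fold lower number from compound 2 to compound 3 (0.25 log units; within the scatter). Compound 4 `O=C(Nc1ccc(-n2ncc3cccnc32)cc1)Nc1ccc(Cl)c(C(F)(F)F)c1` is not yet measured. It differs from compound 3 by a group of 9 heavy atoms (6 carbon, 3 nitrogen; one five-membered aromatic ring with 2 hetero atoms, one six-membered aromatic ring with 1 hetero atom) in place of a group of 9 heavy atoms (6 carbon, 3 nitrogen; one five-membered aromatic ring with 2 hetero atoms, one six-membered aromatic ring with 1 hetero atom), on an aromatic carbon; the two have the same atoms, joined differently. The steps bearing on this exchange all alter the same bicyclic group: a 1.9-fold higher number from compound 1 to compound 2 (0.28 log units; within the scatter), a 1.1-fold higher number from compound 1 to compound 3 (0.03 log units; within the scatter) and a 1.8-fold lower number from compound 2 to compound 3 (0.25 log units; within the scatter), none beyond the scatter, so no step beyond the scatter is expected in this assay in either direction. Compound 4 is therefore expected to give 1400 nM, within 700 nM to 2800 nM. The expected step is no change at the digits printed from compound 3 to compound 4 (within the scatter).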

Compound 4, half-maximal inhibitory concentration: 16600 nM
Estimate against measurement, compound 4: 12-fold (1.07 log units) below; measured number above the stated range.
By their numbers in this assay, from the lowest: compounds 1, 3 and 2 (each within the scatter of the next); then compound 4.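

In this assay, for the compounds shown here, this position proves sensitive to how the same atoms are joined: the exchange gives a 12-fold higher number from compound 3 to compound 4 (1.07 log units; beyond the scatter) and is the first change to the bicyclic group beyond the scatter. Compound 4 also stands apart from the other two compounds, with a 6.6-fold higher number from compound 2 to compound 4 (0.82 log units; beyond the scatter) and a 13-fold higher number from compound 1 to compound 4 (1.11 log units; beyond the scatter). No measurement bears on the reason for this shift. Open, as far as these compounds go, is whether an amine or a methoxy group on the six-membered ring of compound 4 would bring its number back towards that of compound 3.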